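This account rests on a few compounds, and the source may have more. Where it says the series, first, only, none or still open, it means among the compounds named here.

Measured compounds:
- compound 1 `NC(=O)C1(NC(=O)[C@@H](CCCC(=O)O)NC(=O)[C@@H](CCCCNC(=O)/C=C/c2cccnc2)NC(=O)c2ccc(Nc3nc4ccccc4[nH]3)cc2)CCCCC1`: 1.83
- compound 2 `NC(=O)C1(NC(=O)[C@@H](CCCC(=O)O)NC(=O)[C@@H](CCCCNC(=O)/C=C/c2cccnc2)NC(=O)c2cccc(Nc3nc4ccccc4[nH]3)c2)CCCCC1`: 2.12

In a physicochemical assay for lipophilicity (on this read-out lower numbers stand for lower lipophilicity and higher numbers for higher lipophilicity), compound 1 gives 1.83, the lower of the two numbers recorded, while compound 2 gives 2.12; the two values lie within the usual scatter of each other, so no order can be read from them. The unmeasured compound 3 `Cc1ccccc1NC(=O)Nc1ccc(C(=O)N[C@H](CCCCNC(=O)/C=C/c2cccnc2)C(=O)N[C@H](CCCC(=O)O)C(=O)NC2(C(N)=O)CCCCC2)cc1` differs from compound 1 in one place: (2-methylphenyl)carbamoyl in place of 1H-benzimidazol-2-yl on a nitrogen on an aromatic ring. Among the compounds with values here, no measured pair shows this exact change, so the expected step must be judged from the groups themselves. A (2-methylphenyl)carbamoyl group, with one more heavy atom and one fewer ring than the 1H-benzimidazol-2-yl it replaces, is expected to shift lipophilicity only modestly upwards, at the edge of the scatter. The step expected in this assay is a number 0.37 log units higher from compound 1 to compound 3 (beyond the scatter). Compound 3 is therefore estimated at 2.2, within a range from 1.6 to 2.9.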

Compound 3, partition coefficient: 3.26
Compound 3: the middle estimate sits 1.06 log units below what was measured, outside the stated range (above it).
By their numbers in this assay, from the lowest: compounds 1 and 2 (each within the scatter of the next); then compound 3.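

In this assay the group on a nitrogen on an aromatic ring proves able to move the number by far more than the scatter: putting (2-methylphenyl)carbamoyl in place of 1H-benzimidazol-2-yl gives a number 1.43 log units higher from compound 1 to compound 3 (beyond the scatter). Within the data shown here, compound 1 and compound 2 offered no step between compounds differing in one place, so this is the first sign of how much a change of this group can matter. The hydrogen-bond donor and acceptor counts of the two groups are the same, and nothing available explains the size of the step.

Still open, on these data alone, is whether a phenylcarbamoyl group, lacking the methyl, would give a similar number, or whether a (2-aminophenyl)carbamoyl group would. Also open, as far as these compounds go, is whether the same change made on compound 2 would give a step of similar size.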